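Removing the ring fluorine of compound 2: an expected weaker hit

This account rests on a few compounds, and the source may have more. Where it says the series, first, only, none or still open, it means among the compounds named here.

Compound 1 `NC1(CCn2ncc(=O)[nH]c2=O)OC(=O)C(OCc2ccccc2)=C1OCc1ccccc1` — > 100000 nM
Compound 2 `NC1(CCn2cc(F)c(=O)[nH]c2=O)OC(=O)C(OCc2ccccc2)=C1OCc1ccccc1` — 42800 nM
Compound 3 `NC1(CCn2ccc(=O)[nH]c2=O)OC(=O)C(OCc2ccccc2)=C1OCc1ccccc1` — to be measured

In a functional assay on HepG2 cells (Homo sapiens) for inhibition, read by MTT assay, with a stated time of 72 h (on this read-out lower numbers stand for stronger inhibition and higher numbers for weaker inhibition), compound 1 gives only a limit, > 100000 nM. Compound 2 gives 42800 nM, the single number shown. The step of an at least 2.3-fold lower number from compound 1 to compound 2 (0.36 log units; beyond the scatter) runs against the limit (the limit of > 100000 nM in this assay, at which 1 of the 2 values shown sits). Among the measured compounds shown here, compound 3 differs from compound 2 by hydrogen in place of fluoro on an aromatic carbon, a change of a different kind from the measured step, so the one measured step offers no direct guide. A weakening of modest size is expected for compound 3 in this assay, as the step of a 2.1-fold higher number from compound 2 to compound 3 (0.32 log units; beyond the scatter). Compound 3 is estimated at 90000 nM, between 30000 nM and 300000 nM.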

Compound 3, half-maximal inhibitory concentration: > 100000 nM
Compound 3: no number, only a limit (the forecaster's own chance of this, stated with the estimate: 50%); at least 1.1-fold (0.04 log units) between middle value and limit.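

In this assay, among the compounds shown here, hydrogen in place of fluoro on an aromatic carbon gives an at least 2.3-fold higher number from compound 2 to compound 3 (0.36 log units; beyond the scatter), the first reading of a change at this carbon alone; of the three compounds, only compound 2, which carries the fluoro, gives a number. As far as these compounds go, compound 3 gives only a limit, so the full size of this loss stays unknown. The step between compound 1 and compound 3 cannot be read because both compounds sit at a limit: the limit of > 100000 nM in this assay, at which 2 of the 3 values shown sit.

From the compounds shown here alone, whether chloro, methyl or an amine on this carbon would match the fluoro remains open. So does whether a longer chain would change the number of compound 2.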